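A few compounds are considered here, and "the series" means these few. Any claim that something is new, unique, unknown or untested is made for them only; others in the source may bear on it.

Measured compounds: compound 1 `C=C(Br)C(=O)Nc1ccc(C(=O)/C=C/c2cccc(OC)c2)cc1`, 1100 nM; compound 2 `C=C(Br)C(=O)Nc1ccc(C(=O)/C=C/c2ccc(OC)c(OC)c2)cc1`, 1300 nM; compound 3 `Nc1ccc(/C=C/C(=O)c2ccccc2)cc1`, 88000 nM.

These numbers come from a functional assay on L1210 cells (Mus musculus) for antiproliferative activity, with a stated time of 48 h; on this read-out higher numbers stand for weaker inhibition and lower numbers for stronger inhibition. Compound 3 gives the highest number of the three, beyond the scatter from both compound 1 and compound 2. The difference between the core of compound 3 and the core of compound 1 is not broken down here.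

Compound 4 `COc1cccc(C(=O)/C=C/c2ccc(N)cc2)c1` is not yet measured in this assay. It differs from compound 3 by methoxy in place of hydrogen on an aromatic carbon. The same kind of change is measured between compound 1 and compound 2, (methoxy in place of hydrogen on an aromatic carbon), with a step of a 1.2-fold higher number from compound 1 to compound 2 (0.07 log units; within the scatter). The places are not the same: in compound 2 the methoxy sits ortho to a methoxy group and para to a large group, in compound 4 meta to a large group.

Because a 1.2-fold higher number from compound 1 to compound 2 (0.07 log units; within the scatter) lies within the scatter, the expected step for compound 4 is a 1.2-fold lower number from compound 3 to compound 4 (0.07 log units; within the scatter). Compound 4 is estimated at 75000 nM, between 35000 nM and 160000 nM.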

Compound 4, half-maximal inhibitory concentration: 38000 nM
The estimate for compound 4 lay 2.0-fold (0.30 log units) above the measured number; the range from low to high includes it.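

On the core of compound 3, methoxy in place of hydrogen on an aromatic carbon gives a 2.3-fold lower number from compound 3 to compound 4 (0.36 log units; beyond the scatter) in this assay. The change therefore does not carry over at one size from one core to another in this series, as the two steps differ: the same change on two cores in this assay, a 1.2-fold higher number (0.07 log units; within the scatter) from compound 1 to compound 2 and a 2.3-fold lower number (0.36 log units; beyond the scatter) from compound 3 to compound 4, 2.7-fold (0.44 log units) apart, beyond the scatter of two such steps This does not show what separates them, since the methoxy stands at different places and the cores differ as well, and these two steps alone cannot tell those two differences apart.

The compounds shown leave open whether the step on the core of compound 3 would hold with methoxy elsewhere on that ring. They also leave open whether a hydroxy group or a fluorine atom in the same place would give a step of similar size.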